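Swapping selenium for sulfur on a bis-acylated isoselenourea

This account rests on a few compounds, and the source may have more. Where it says the series, first, only, none or still open, it means among the compounds named here.

Measured compounds:
Compound 1 `O=C(/N=C(/NC(=O)c1ccco1)[Se]Cc1ccccc1)c1ccco1`: 8800 nM
Compound 2 `C[Se]/C(=N\C(=O)c1cnc2ccccc2c1)NC(=O)c1cnc2ccccc2c1`: 20300 nM

In an ADME assay on MCF-10A cells (Homo sapiens) for cytotoxicity, read by MTT assay, with a stated time of 72 h (on this read-out higher numbers stand for weaker inhibition of growth and lower numbers for stronger inhibition of growth), compound 2 gives 20300 nM, the highest of the two numbers; its nearest neighbour, compound 1, gives 8800 nM, a gap that lies beyond the scatter. Compound 3 `CS/C(=N\C(=O)c1cnc2ccccc2c1)NC(=O)c1cnc2ccccc2c1` differs from compound 2 by a group of 2 heavy atoms (1 carbon, 1 sulfur; no ring) in place of a group of 2 heavy atoms (1 carbon, 1 selenium; no ring), on a carbon with a double bond to nitrogen. Among the compounds with values here, no measured pair shows this exchange, so its effect is not known here. The expected step is a 1.7-fold higher number from compound 2 to compound 3 (0.24 log units; within the scatter), towards weaker inhibition of growth, with wide uncertainty. Compound 3 is thus estimated at 35000 nM, in a range from 12000 nM to 100000 nM.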

Compound 3, concentration for 50% growth inhibition: 500 nM
For compound 3 the middle estimate is 70-fold (1.85 log units) above the measured one; measured number outside the range, below it.
By their numbers in this assay, from the lowest: compound 3; then compound 1; then compound 2.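

In this assay, putting methylsulfanyl in place of the selenium-bearing group on a carbon with a double bond to nitrogen gives a 41-fold lower number from compound 2 to compound 3 (1.61 log units; beyond the scatter) towards stronger inhibition of growth. This shows that this single position can strongly shift the read-out while the rest of the molecule stays unchanged. Nothing available here explains a step of this size.

On these data alone, whether a longer chain on the sulfur or an amine on that carbon would keep this stronger inhibition remains open. As far as these compounds go, it is also open whether the same exchange would act alike on the core of compound 1.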